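Chloro for Butoxy on the Anilino Ring of a Furazano-Pyrazine Core

A few compounds are considered here, and "the series" means these few. Any claim that something is new, unique, unknown or untested is made for them only; others in the source may bear on it.

Measured compounds:
compound 1, `CCCCOc1ccc(Nc2nc3nonc3nc2O)cc1`, 3700 nM
compound 2, `Oc1nc2nonc2nc1Nc1cccc2ccccc12`, 20400 nM

In an assay on mitochondria from L6 cells (Rattus norvegicus) for activation, with a stated time of 90 min (on this read-out lower numbers stand for an effect already at smaller amounts and higher numbers for an effect only at larger amounts of compound), compound 1 gives 3700 nM, the lowest of the two numbers at hand. Compound 2, which carries a naphthyl group on the same shared core, gives 20400 nM in this assay, a number well beyond the scatter of compound 1. Among the compounds with values here, no step between two measured compounds that differ in a single place has been worked out, so the effect of one change at a time cannot be read from the pair; only the two values themselves are known.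

Compound 3, `Oc1nc2nonc2nc1Nc1ccc(Cl)cc1`, has not yet been measured in this assay. It differs from compound 1 as follows: chloro in place of butoxy on an aromatic carbon.

Within the data shown here, with no single-place step to lean on, the expectation for compound 3 rests on the value of compound 1 alone, 3700 nM, and on the size of the change. A modest shift toward higher numbers, at the edge of the scatter, is expected, that is a 1.6-fold higher number from compound 1 to compound 3 (0.21 log units; within the scatter). Compound 3 is thus estimated at 6000 nM, with a range from 1500 nM to 25000 nM.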

Compound 3, half-maximal effective concentration: 11700 nM
The estimate for compound 3 lay 2.0-fold (0.29 log units) below the measured number; low and high end bracket the measured number.
By their numbers in this assay, from the lowest: compound 1; then compounds 3 and 2 (each within the scatter of the next).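

In this assay, within the data shown here, chloro in place of butoxy on an aromatic carbon gives a 3.2-fold higher number from compound 1 to compound 3 (0.50 log units; beyond the scatter) and thus provides the first step here that changes one place only; though modest, it lies beyond the scatter. This shows that the position, para to a large group on the six-membered aromatic ring, is not indifferent to what it carries: with everything else unchanged, the number moves when butoxy, with its 5 heavy atoms and its hydrogen-bond acceptor, gives way to chloro, with 1 heavy atom and no acceptor. The change alters the group's size, its atoms and its acceptor count together, and nothing measured here ties the step to any one of these or to any cause.

Still open, as far as these compounds go, is whether the chain or its oxygen matters more, a question that methoxy, hexyloxy or a plain butyl group at the same place would help to separate. From the compounds shown here alone, it is equally open how an amine or a carboxylic acid there would shift the number, and whether it would move up or down from that of compound 1.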